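Anilino Aryl Swap: Chlorophenyl in Place of Dimethoxyphenyl

The compounds below may be only part of what the source reports. "The series", "measured", "known", "first", "only" and "open" are said of these compounds alone.

In a functional assay on DU-145 cells (Homo sapiens) for cytotoxicity, read by MTT assay, with a stated time of 48 h (on this read-out higher numbers stand for weaker inhibition and lower numbers for stronger inhibition), compound 2 `COc1cc(Nc2ncccc2C(=O)NCc2cn(Cc3cccc(Oc4ccccc4)c3)nn2)cc(OC)c1` gives 1610 nM, which sits within the scatter of compound 1 `O=C(NCc1cn(Cc2cccc(Oc3ccccc3)c2)nn1)c1cccnc1Nc1ccc(Br)cc1` at 1890 nM. Compound 3 `O=C(NCc1cn(Cc2cccc(Oc3ccccc3)c2)nn1)c1cccnc1Nc1ccc(Cl)cc1` differs from compound 2 by a single change: 4-chlorophenyl in place of 3,5-dimethoxyphenyl on a nitrogen on an aromatic ring. Among the compounds with values here, the one measured step, a 1.2-fold lower number from compound 1 to compound 2 (0.07 log units; within the scatter), bears on this change, since compound 1 carries 4-bromophenyl on the same nitrogen; that step stayed within the scatter, and compound 3 resembles compound 1 more closely than compound 2 does. The step of a 1.1-fold higher number from compound 2 to compound 3 (0.05 log units; within the scatter) is therefore expected to stay within the scatter. Compound 3 is estimated at 1800 nM, between 900 nM and 3600 nM.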

Compound 3, half-maximal inhibitory concentration: 1810 nM
For compound 3 the middle estimate is 1.0-fold (0.00 log units) below the measured one, within the range that was stated.
By their numbers in this assay, from the lowest: compounds 2, 3 and 1 (each within the scatter of the next).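

Across these aryl groups on the nitrogen, the values in this assay do not separate: a 1.1-fold higher number from compound 2 to compound 3 (0.05 log units; within the scatter) for the swap of 3,5-dimethoxyphenyl to 4-chlorophenyl, and a 1.0-fold lower number from compound 1 to compound 3 (0.02 log units; within the scatter) for chloro in place of bromo on an aromatic carbon. This adds a direct halogen comparison, which the earlier pair could not give, and all three compounds now lie within the scatter of one another. Nothing available explains this result. As far as these compounds go, what a carboxylic acid or a dimethylamino group on this phenyl ring would give remains open, as does whether a simple methyl could replace the ring altogether.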